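A few compounds are considered here, and "the series" means these few. Any claim that something is new, unique, unknown or untested is made for them only; others in the source may bear on it.

compound 1 `CCc1ccc(/C=C/C(O)=C2/C(=O)C(C)=C(OC)C(C)(C)C2=O)cc1`: 6.9 ug/mL
compound 2 `C=Cc1ccccc1/C=C/C(O)=C1/C(=O)C(C)=C(OC)C(C)(C)C1=O`: 1.9 ug/mL

Within the data shown here, in a functional assay on KB cells (Homo sapiens) for cytotoxicity (on this read-out lower numbers stand for an effect already at smaller amounts and higher numbers for an effect only at larger amounts of compound), compound 2 gives 1.9 ug/mL as the lowest of the two numbers so far. The next change leads to compound 3 `COC1=C(C)C(=O)/C(=C(O)/C=C/c2ccco2)C(=O)C1(C)C` and puts furan-2-yl in place of 2-vinylphenyl on a double-bonded chain carbon bound to a double-bonded chain carbon. Among the measured compounds shown here, only one measured step bears on this place. It is a 3.6-fold lower number from compound 1 to compound 2 (0.56 log units; beyond the scatter) and counts as modest, though beyond the scatter. That step swaps 4-ethylphenyl for 2-vinylphenyl, so the series holds no measurement with a furan-2-yl group, and neither the size nor the direction of the new step is settled by the data. Compound 2 holds the lower number, and a return toward the level of compound 1 at 6.9 ug/mL seems the likelier outcome. A modest rise is therefore expected in this assay (a 2.4-fold higher number from compound 2 to compound 3 (0.37 log units; beyond the scatter)) with a wide margin on both sides. For compound 3 the estimated value is 4.5 ug/mL with an expected range from 1.5 ug/mL to 13 ug/mL in this read-out.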

Compound 3, concentration for half-maximal effect: 9.9 ug/mL
The estimate for compound 3 lay 2.2-fold (0.34 log units) below the measured number; measured number inside the range.
By their numbers in this assay, from the lowest: compound 2; then compounds 1 and 3 (each within the scatter of the next).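

In this assay, among these compounds, this place on a double-bonded chain carbon bound to a double-bonded chain carbon now shows a clear loss on leaving 2-vinylphenyl for furan-2-yl, with a 5.2-fold higher number from compound 2 to compound 3 (0.72 log units; beyond the scatter) as the largest step so far. The other step, a 1.4-fold higher number from compound 1 to compound 3 (0.16 log units; within the scatter), leaves furan-2-yl and 4-ethylphenyl unseparated in this assay, even though the two groups differ in ring size, in heavy atoms and in the hetero atom that furan-2-yl brings. Among the three compounds, the lower number therefore belongs to compound 2 alone, and a five-membered aromatic ring with an oxygen does not carry it over.

The compounds shown leave open whether that lower number follows the vinyl group itself or its place on the phenyl ring, a question that a 4-vinylphenyl or a 2-ethylphenyl group at this place would answer, and how a phenyl ring bearing an amine or a carboxylic acid would read in the same assay. Nothing at hand explains the size of either step or the standing of compound 2.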